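The compounds below may be only part of what the source reports. "The series", "measured", "known", "first", "only" and "open" are said of these compounds alone.

Working notes on the series. For the measured compounds named here, compound 1, `Nc1nc(Cl)c2ncn(Cc3ccc(CCl)cc3)c2n1`, is the only member with a number in hand: in a functional assay on SNB-19 cells (Homo sapiens) for cytotoxicity, read by sulforhodamine B assay, with a stated time of 48 h (on this read-out higher numbers stand for weaker inhibition of growth and lower numbers for stronger inhibition of growth), compound 1 gives 20000 nM. Compound 2, `ClCc1ccccc1Cn1cnc2nc(Cl)nc(Cl)c21`, was run in this assay, where compound 2 is recorded as "not determined" (no result reported), so compound 2 stands without a number and nothing can be said of its place relative to compound 1. Compound 3, `ClCc1ccccc1Cn1cnc2ncnc(Cl)c21`, is yet to be measured in this assay.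

The step from compound 2 to compound 3 is hydrogen in place of chloro on an aromatic carbon. Going by the values given here, with no number for compound 2 and no step between measured compounds, the size and direction of this change cannot be read from the data; the only anchor is the weak growth inhibition of compound 1, which keeps one chloro on the core, as does compound 3. The expectation is that compound 3 also shows only weak inhibition in this assay, estimated at 20000 nM with a range of 5000 nM to 60000 nM.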

Compound 3, concentration for total growth inhibition: > 100000 nM
Compound 3: a limit, no number (the forecaster's own chance of this, stated with the estimate: 35%); middle value at least 5.0-fold (0.69 log units) from the limit.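

No step can be read between compound 2 and compound 3: compound 2 has no number, and the result for compound 3 is a limit, not a number. As far as these compounds go, whether hydrogen in place of chloro changes growth inhibition in this assay, and by how much, stays open.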